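Restoring the Secondary Amine with a Methoxybenzyl Group

This account rests on a few compounds, and the source may have more. Where it says the series, first, only, none or still open, it means among the compounds named here.

The series shares a bis(trifluoromethyl)benzenesulfonamide linked through a three-carbon chain to an amine. Compound 1 `CC(C)(C)c1ccc(CNCCCNS(=O)(=O)c2cc(C(F)(F)F)cc(C(F)(F)F)c2)cc1` gives 2100 nM in a functional assay on Capan-2 cells (Homo sapiens) for inhibition, read by MTT assay, with a stated time of 72 h (on this read-out lower numbers stand for stronger inhibition of growth and higher numbers for weaker inhibition of growth), and compound 2 `O=S(=O)(NCCCNCc1ccc(Cl)c(Cl)c1)c1cc(C(F)(F)F)cc(C(F)(F)F)c1` gives 1800 nM; the step of a 1.2-fold lower number from compound 1 to compound 2 (0.07 log units; within the scatter) is one of exchanging the substituted benzyl group. Compound 3 `CN(CCCNS(=O)(=O)c1cc(C(F)(F)F)cc(C(F)(F)F)c1)Cc1ccccc1` gives 46000 nM, the highest number of the three, and the step of a 26-fold higher number from compound 2 to compound 3 (1.41 log units; beyond the scatter) shows how much the read-out rose when the secondary amine bearing a (3,4-dichlorobenzyl) group became a benzyl(methyl)amino group.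

Compound 4 `COc1cccc(CNCCCNS(=O)(=O)c2cc(C(F)(F)F)cc(C(F)(F)F)c2)c1` differs from compound 3 by (3-methoxybenzyl)amino in place of benzyl(methyl)amino on a saturated chain carbon, three bonds along the chain from a sulfonamide nitrogen. This change reverses the essential feature of the step from compound 2 to compound 3: the tertiary amine returns to a secondary one carrying a substituted benzyl group, now with a methoxy rather than chlorines or a tert-butyl group. Both earlier secondary amines, in compound 1 and compound 2, gave numbers close to one another, so the large step of a 26-fold higher number from compound 2 to compound 3 (1.41 log units; beyond the scatter) is the one that bears on this change, and a step of similar size in the opposite direction is expected. Compound 4 is therefore estimated at 3000 nM in this assay, within a range of 1000 nM to 10000 nM, corresponding to an expected step of a 15-fold lower number from compound 3 to compound 4 (1.19 log units; beyond the scatter).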

Compound 4, concentration for 50% growth inhibition: 6400 nM
The estimate for compound 4 lay 2.1-fold (0.33 log units) below the measured number; measured number inside the range.
By their numbers in this assay, from the lowest: compounds 2 and 1 (each within the scatter of the next); then compound 4; then compound 3.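

In this assay, the (3-methoxybenzyl)amino group on the saturated chain carbon recovers much of the ground separating compound 3 from the other secondary amines, with a 7.2-fold lower number from compound 3 to compound 4 (0.86 log units; beyond the scatter) and a reading that remains short of both compound 1 and compound 2. The earlier pair suggested that the substituted benzyl group might matter little, but compound 4 shows otherwise: there is a 3.6-fold higher number from compound 2 to compound 4 (0.55 log units; beyond the scatter) and a 3.0-fold higher number from compound 1 to compound 4 (0.48 log units; beyond the scatter) as well, both beyond the scatter, so a secondary amine alone does not fix the number and the aryl group on that carbon also counts. Nothing measured here accounts for these differences.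

The step between compound 3 and compound 4 removes the methyl group on the amine and adds the methoxy group together, so the share of each remains unresolved, and an unsubstituted benzylamino group on the same chain would separate them. Also open, on these data alone, is how a hydroxyl group or a nitrile on the benzyl ring, or a longer chain between the amine and the sulfonamide nitrogen, would shift the number.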